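This account rests on a few compounds, and the source may have more. Where it says the series, first, only, none or still open, it means among the compounds named here.

In a functional assay on HeLa cells (Homo sapiens) for inhibition, with a stated time of 72 h (on this read-out higher numbers stand for weaker inhibition and lower numbers for stronger inhibition), compound 1 (`COc1ccccc1-c1ccc(CNc2nc(NC3CCC(N)CC3)nc3c2ncn3C2CCCC2)cc1`) gives 333 nM and compound 2 (`NC1CCC(Nc2nc(NCc3ccc(-c4ccco4)cc3)c3ncn(C4CCCC4)c3n2)CC1`) gives 71 nM as the lower of the two numbers. Compound 3 (`NC1CCC(Nc2nc(NCc3ccc(-c4ccsc4)cc3)c3ncn(C4CCCC4)c3n2)CC1`) has thiophen-3-yl in place of furan-2-yl on an aromatic carbon. Among the measured compounds shown here, the one measured step at this place is a 4.7-fold lower number from compound 1 to compound 2 (0.67 log units; beyond the scatter) when furan-2-yl replaces 2-methoxyphenyl. Here one five-membered aromatic ring with 1 hetero atom replaces another, so no step beyond the scatter is expected in this assay for this swap. The expected outcome is a 1.2-fold higher number from compound 2 to compound 3 (0.08 log units; within the scatter) on this estimate. In this assay the estimate for compound 3 is 85 nM with a range from 30 nM to 220 nM in that assay.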

Compound 3, half-maximal inhibitory concentration: 220 nM
For compound 3 the middle estimate is 2.6-fold (0.41 log units) below the measured one; measured number inside the range.
By their numbers in this assay, from the lowest: compound 2; then compounds 3 and 1 (each within the scatter of the next).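

In this assay the exchange of one five-membered aromatic ring with 1 hetero atom for another is not silent at this position, giving a 3.1-fold higher number from compound 2 to compound 3 (0.49 log units; beyond the scatter). Measured against 2-methoxyphenyl, thiophen-3-yl gives a 1.5-fold lower number from compound 1 to compound 3 (0.18 log units; within the scatter), so the advantage of furan-2-yl over 2-methoxyphenyl does not carry over to thiophen-3-yl. No measurement available here explains the difference. The compounds shown leave open whether the hetero atom itself or its point of attachment decides the outcome, since furan-2-yl and thiophen-3-yl differ in both. Furan-3-yl and thiophen-2-yl would separate the two.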